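From 3-carboxyazetidin-1-yl to 3-carboxypyrrolidin-1-yl in compound 3

This account rests on a few compounds, and the source may have more. Where it says the series, first, only, none or still open, it means among the compounds named here.

Measured in a functional assay on HeLa cells (Homo sapiens) for antiproliferative activity, read by CCK-8 assay, with a stated time of 48 h; a lower number here means a stronger inhibitor, a higher number a weaker inhibitor:
- compound 1 (`COc1ccc(/C=C\c2cc(OC)c(OC)c(OC)c2)cc1OCc1ccc(CN2CC[C@H](C(=O)O)C2)cc1`): > 10000 nM (a limit)
- compound 2 (`COc1ccc(/C=C\c2cc(OC)c(OC)c(OC)c2)cc1OCc1ccc(CN2CC(C(=O)O)C2)cc1`): 6500 nM

Within the data shown here, compound 2 at 6500 nM holds the only actual number so far. Compound 1 has only a limit (the limit of > 10000 nM in this assay, at which 1 of the 2 values shown sits). Compound 3 (`COc1ccc(/C=C\c2cc(OC)c(OC)c(OC)c2)cc1OCc1ccc(CN2CC[C@@H](C(=O)O)C2)cc1`) carries 3-carboxypyrrolidin-1-yl in place of 3-carboxyazetidin-1-yl on a saturated chain carbon bound to an aromatic carbon. Among the measured compounds shown here, one measured step bears on this exchange, running in the opposite direction (an at least 1.5-fold lower number from compound 1 to compound 2 (0.18 log units; that floor lies within the scatter)). No measurement addresses the defined stereocentre of compound 3. In this assay a small move to a higher number is therefore expected, possibly none beyond the scatter. The expected size is given by the estimate (a 1.5-fold higher number from compound 2 to compound 3 (0.19 log units; within the scatter)). For compound 3 the estimated value is 10000 nM (expected range 4000 nM to 25000 nM).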

Compound 3, half-maximal inhibitory concentration: 12800 nM
Beside the measured number, compound 3's estimate is 1.3-fold (0.11 log units) below it; the range from low to high includes it.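

Among these compounds, with compound 3, the exchange of 3-carboxyazetidin-1-yl for 3-carboxypyrrolidin-1-yl on a saturated chain carbon bound to an aromatic carbon can be sized between two actual numbers for the first time in this assay: a 2.0-fold higher number from compound 2 to compound 3 (0.29 log units; within the scatter). At this place, therefore, the two carboxylic acid rings are not told apart by this read-out. Compound 3 also forms a pair with compound 1 that could speak to the stereocentre, but compound 1 has only a limit, so the step between them cannot be read: the limit of > 10000 nM in this assay, at which 1 of the 3 values shown sits.

What the drawn configuration at the saturated ring carbon does in this assay therefore stays open, even for this pair: the fact that compounds 1 and 3 differ only in the configuration as drawn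
The compounds shown also leave open whether a methyl ester or a primary amide in place of the carboxylic acid, or a longer chain at this place, would give a different number.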